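Working notes: from compound 2 to compound 3

The source may report more compounds than this note shows. Statements on the series, on what has been measured and on what is new or still open speak of the compounds shown alone.

Measured so far:
compound 1 `O=C(NCc1ccccc1)c1ccccc1OCc1ccccc1`: 34200 nM
compound 2 `O=C(Nc1cccnc1)c1ccccc1OCc1cccc(F)c1`: 1600 nM

In an assay on lysate for inhibition of phosphatidylcholine:ceramide cholinephosphotransferase 2 (Homo sapiens), read by HPLC, with stated times of 30 min and 2 h (on this read-out lower numbers stand for stronger inhibition and higher numbers for weaker inhibition), compound 2 gives 1600 nM, the lower of the two numbers shown. Compound 1 gives 34200 nM, a gap beyond the scatter. Compound 3 `O=C(Nc1cccnc1)c1ccccc1OCc1cccc(Cl)c1F` differs from compound 2 by 3-chloro-2-fluorophenyl in place of 3-fluorophenyl on a saturated chain carbon bound to an oxygen on an aromatic ring. Among the compounds with values here, no pair of measured compounds shows a change of this kind, so there is no step to lean on. The expected step is a 1.5-fold lower number from compound 2 to compound 3 (0.16 log units; within the scatter), which is not beyond the scatter. Compound 3 is estimated at 1100 nM, with a range from 350 nM to 3500 nM.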

Compound 3, half-maximal inhibitory concentration: 3100 nM
Compound 3: middle estimate off by 2.8-fold (0.45 log units), on the low side; measured number inside the range.
By their numbers in this assay, from the lowest: compounds 2 and 3 (each within the scatter of the next); then compound 1.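

In this assay, 3-chloro-2-fluorophenyl in place of 3-fluorophenyl on a saturated chain carbon bound to an oxygen on an aromatic ring gives a 1.9-fold higher number from compound 2 to compound 3 (0.29 log units; within the scatter). Within the data shown here, this is the first single-place reading: at this position, 8 heavy atoms in place of 7 leave the number within the scatter. Nothing available bears on the reason for this result. Still open, going by these compounds, is whether an amine or a carboxylic acid on this ring would give a step beyond the scatter. Compound 1 differs from compound 2 in more than one place, so its gap cannot be assigned to any single change.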